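This account rests on a few compounds, and the source may have more. Where it says the series, first, only, none or still open, it means among the compounds named here.

Compound 1 `CCC[C@H](N)C(=O)NS(=O)(=O)OC[C@H]1O[C@@H](n2cnc3c(N)ncnc32)[C@H](O)[C@@H]1O` gives 4700 nM in a functional assay on PBMC cells (Homo sapiens) for inhibition; on this read-out lower numbers stand for stronger inhibition and higher numbers for weaker inhibition.
Compound 2 `CC(C)C[C@H](N)C(=O)NS(=O)(=O)OC[C@H]1OC[C@@H](n2cnc3c(N)ncnc32)[C@H](O)[C@@H]1O` gives 1000 nM.
Compound 3 `CC(C)C[C@H](N)C(=O)NS(=O)(=O)OC[C@H]1OC[C@@H](n2cnc3c(N)ncnc32)C[C@@H]1O` gives 6800 nM.

Among these three numbers compound 1 stands second highest. Its nearest neighbour is compound 3, whose number is within the usual scatter of that of compound 1, so the two cannot be told apart. Compound 2 is the furthest away, with a lower number that lies beyond the scatter.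

The compound still to be measured is compound 4 `Nc1ncnc2c1ncn2[C@@H]1O[C@H](COS(=O)(=O)NC(=O)[C@@H]2CSCN2)[C@@H](O)[C@H]1O`. Relative to compound 1 it carries a single change: 1,3-thiazolidin-4-yl in place of 1-aminobutyl on a carbonyl carbon.

Among the compounds with values here, only one step between measured compounds is available, a 6.8-fold higher number from compound 2 to compound 3 (0.83 log units; beyond the scatter). It concerns a hydroxy on a saturated ring carbon of the shared core and not the group on the carbonyl carbon, so it says nothing direct about the change from compound 1 to compound 4. Compounds 1 and 2 differ in more than one place, so their two values only show that a different chain together with a different core gave a lower number. Within the data shown here, no measured step therefore bears on the present change, and the expectation must stay wide.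

Compound 4 is expected to give 5000 nM in this assay, within a range from 1500 nM to 20000 nM; the expected step is a 1.1-fold higher number from compound 1 to compound 4 (0.03 log units; within the scatter), that is, essentially none beyond the scatter.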

Compound 4, half-maximal inhibitory concentration: 550 nM
Compound 4: middle estimate off by 9.1-fold (0.96 log units), on the high side, and the stated range ends above it.
By their numbers in this assay, from the lowest: compounds 4 and 2 (each within the scatter of the next); then compounds 1 and 3 (each within the scatter of the next).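

In this assay, the group on the carbonyl carbon turns out to matter: replacing the open-chain 1-aminobutyl with 1,3-thiazolidin-4-yl, a five-membered non-aromatic ring with 2 hetero atoms, gives an 8.5-fold lower number from compound 1 to compound 4 (0.93 log units; beyond the scatter). Within the data shown here, the only earlier step concerned a hydroxy on a saturated ring carbon of the core, so this is the first direct reading at this position, and it shows that the assay responds to a change there even when the core stays the same and both groups have 5 heavy atoms. No measurement shown here explains why the number falls.

This single step cannot separate the contribution of closing the ring from that of the sulfur, and a group with the same five-membered ring but a carbon in place of the sulfur, or an open chain carrying a sulfur atom, would be needed to pull the two apart. It also leaves open whether 1,3-thiazolidin-4-yl would give a similar step on the core of compound 2, where the group on the carbonyl carbon is a different chain.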